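Swapping the fluoro of compound 3 for hydrogen

This account rests on a few compounds, and the source may have more. Where it says the series, first, only, none or still open, it means among the compounds named here.

In a functional assay on WIL2 cells (Homo sapiens) for inhibition (on this read-out lower numbers stand for stronger inhibition and higher numbers for weaker inhibition), compound 1 `C#CCN(Cc1cc2c(O)nc(C)nc2cc1C)c1ccc(C(=O)N[C@@H](CCC(=O)O)C(=O)N(C)[C@@H](CCC(=O)O)C(=O)O)c(F)c1` gives 350 nM, compound 2 `Cc1nc(O)c2cc(CN(C)c3ccc(C(=O)N[C@@H](CCC(=O)O)C(=O)N(C)[C@@H](CCC(=O)O)C(=O)O)c(F)c3)ccc2n1` gives 2300 nM and compound 3 `Cc1nc(O)c2cc(CN(C)c3ccc(C(=O)N[C@@H](CCC(=O)O)C(=O)N(C)[C@@H](CCC(=O)O)C(=O)O)c(F)c3)c(C)cc2n1` gives 630 nM. Compound 3 thus stands level with compound 1, with a 1.8-fold higher number from compound 1 to compound 3 (0.26 log units; within the scatter), and clear of compound 2, with a 3.7-fold lower number from compound 2 to compound 3 (0.56 log units; beyond the scatter), for methyl in place of hydrogen on an aromatic carbon. Compound 4 `Cc1nc(O)c2cc(CN(C)c3ccc(C(=O)N[C@@H](CCC(=O)O)C(=O)N(C)[C@@H](CCC(=O)O)C(=O)O)cc3)c(C)cc2n1` arises through (hydrogen in place of fluoro on an aromatic carbon), hydrogen in place of fluoro on an aromatic carbon. Neither measured step touches that carbon, so they show only the size single changes reach here, and no direction can be drawn from them. No shift beyond the scatter is therefore expected. The expected change is a 1.1-fold higher number from compound 3 to compound 4 (0.05 log units; within the scatter). Compound 4 is estimated at 700 nM, within a range of 250 nM to 1900 nM.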

Compound 4, half-maximal inhibitory concentration: 800 nM
Beside the measured number, compound 4's estimate is 1.1-fold (0.06 log units) below it, and the stated range covers the measured number.
By their numbers in this assay, from the lowest: compounds 1, 3 and 4 (each within the scatter of the next, the first and the last beyond it); then compound 2.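

Removing the fluoro from the aromatic carbon ortho to a large group and meta to a large group leaves this assay essentially unmoved, with a 1.3-fold higher number from compound 3 to compound 4 (0.10 log units; within the scatter). Going by these compounds alone, this is the first reading at this carbon, since the earlier steps changed other places, and it shows that here, with the methyl on the shared core, the fluoro can give way to hydrogen without a shift beyond the scatter. No measured evidence bears on why the number holds. The compounds shown leave open whether a chloro or a methoxy group on this carbon would move the number, and whether hydrogen in place of fluoro would read the same with a prop-2-ynyl chain on the nitrogen.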